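The source may report more compounds than this note shows. Statements on the series, on what has been measured and on what is new or still open speak of the compounds shown alone.

In a functional assay on DU-145 cells (Homo sapiens) for inhibition, read by trypan blue exclusion, with a stated time of 72 h (on this read-out lower numbers stand for stronger inhibition and higher numbers for weaker inhibition), compound 1 `Cn1c(=O)c(S(=O)(=O)c2ccc(F)cc2F)cc2cnc(Nc3cccc4[nH]ccc34)nc21` gives 750 nM, the lowest of the three numbers in hand. Compound 2 `COc1ccc(S(=O)(=O)c2cc3cnc(Nc4cccc5[nH]ccc45)nc3n(C)c2=O)cc1` gives 5000 nM in this assay, and compound 3 `O=c1[nH]c2nc(Nc3ccc4[nH]ccc4c3)ncc2cc1S(=O)(=O)c1ccc(F)cc1F` gives 15000 nM. For the measured compounds named here, the only single-place step among them, a 6.7-fold higher number from compound 1 to compound 2 (0.82 log units; beyond the scatter), concerns the group on the sulfonyl sulfur and not the amine side. Compound 4 `Cn1c(=O)c(S(=O)(=O)c2ccc(F)cc2F)cc2cnc(Nc3ccc4cccc(O)c4n3)nc21` differs from compound 1 at the amine: 8-hydroxyquinolin-2-yl in place of 1H-indol-4-yl on a nitrogen on an aromatic ring. Going by the values given here, no measured step changes this group, so there is no direct guide. Since the swap is larger than any step seen, compound 4 is expected to move a 2.7-fold higher number from compound 1 to compound 4 (0.43 log units; beyond the scatter), most likely toward a weaker number. The estimate for compound 4 in this assay is therefore 2000 nM, within 400 nM to 10000 nM.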

Compound 4, half-maximal inhibitory concentration: 5000 nM
Beside the measured number, compound 4's estimate is 2.5-fold (0.40 log units) below it; the range from low to high includes it.
By their numbers in this assay, from the lowest: compound 1; then compounds 2 and 4 (each within the scatter of the next); then compound 3.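

In this assay, 8-hydroxyquinolin-2-yl in place of 1H-indol-4-yl on a nitrogen on an aromatic ring gives a 6.7-fold higher number from compound 1 to compound 4 (0.82 log units; beyond the scatter) and so shows that the amine side, not only the group on the sulfonyl sulfur, shifts the number. At this position, the 1H-indol-4-yl of compound 1 is not matched by the 8-hydroxyquinolin-2-yl of compound 4. No measurement at hand accounts for this step. From the compounds shown here alone, what a plain quinolin-2-yl or an 8-methoxyquinolin-2-yl would give on this nitrogen stays open, and with it whether the hydroxyl has any part in the step.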